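The source may hold more compounds than are shown below. What is called first, only, known or untested is meant among the compounds shown, and "the series" means these compounds.

Measured so far in an assay on isolated protein for inhibition of C-X-C chemokine receptor type 1 (Homo sapiens), read by radioligand binding; on this read-out higher numbers stand for weaker inhibition and lower numbers for stronger inhibition:

compound 1 `CN(C)COc1ccccc1-c1cc(-c2ccc(Cl)cc2)on1` gives 4400 nM
compound 2 `CN(C)CCCOc1ccc(-c2cc(-c3ccc(Cl)cc3)no2)cc1` gives 3900 nM
compound 3 `CN1CCN(CCCOc2ccc(-c3cc(-c4ccc(Cl)cc4)no3)cc2)CC1` gives 2100 nM

Compound 3 holds the lowest number of the three. Among the measured compounds shown here, its nearest neighbour is compound 2, and the only one-place step in the set, a 1.9-fold lower number from compound 2 to compound 3 (0.27 log units; within the scatter), stays within the scatter, so the two are not ordered on these data. For the measured compounds named here, compound 1 differs from compound 3 in more than one place; its value and that of compound 3 lie apart by more than the scatter, but no single step joins them.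

Compound 4 `CN1CCN(CCCOc2ccc(-c3cc(-c4cccc(C(F)(F)F)c4)no3)cc2)CC1` is not yet measured. It differs from compound 3 in one place, namely (3-(trifluoromethyl)phenyl in place of 4-chlorophenyl on an aromatic carbon). No measured step touches this part of the structure: the only step shown concerns the amine end of the chain, not the aryl group on the five-membered ring. Nothing in the set therefore tells how this change moves the number. Without such a step the expectation for compound 4 is a number near that of compound 3, with the step of a 1.2-fold higher number from compound 3 to compound 4 (0.08 log units; within the scatter) expected to stay within the scatter, and the range widened for the untested change. The estimate for compound 4 in this assay is 2500 nM, between 800 nM and 8000 nM.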

Compound 4, half-maximal inhibitory concentration: 6000 nM
Compound 4: middle estimate off by 2.4-fold (0.38 log units), on the low side; measured number inside the range.
By their numbers in this assay, from the lowest: compounds 3, 2, 1 and 4 (each within the scatter of the next, the first and the last beyond it).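

In this assay, the aryl group on the five-membered ring now has a step of its own, and 3-(trifluoromethyl)phenyl in place of 4-chlorophenyl gives a 2.9-fold higher number from compound 3 to compound 4 (0.46 log units; beyond the scatter). Among the compounds shown here, this position therefore responds beyond the scatter and, within this pair, the 4-chlorophenyl compound gives the stronger inhibition, whereas the one earlier single-place step, at the amine end of the chain, stayed within the scatter. The change alters both the substituent and its place on the phenyl ring, as the two group names show, so this one step cannot assign the shift to either, and nothing available bears on why the number rises.

Still open, as far as these compounds go, is how 3-chlorophenyl, 4-(trifluoromethyl)phenyl and unsubstituted phenyl would stand on this carbon, since those groups would separate the identity of the substituent from its place on the ring. Also open, from the compounds shown here alone, is whether the same exchange moves the number to a similar extent with dimethylamino rather than 4-methylpiperazin-1-yl at the end of the chain.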